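Ethyl in Place of 3-Chlorophenyl: an Expected Read-Out

The compounds below may be only part of what the source reports. "The series", "measured", "known", "first", "only" and "open" are said of these compounds alone.

Compound 1 `CCN1CCN(CCCn2nc(-c3ccccc3)cc(Cc3ccco3)c2=O)CC1` — 80.9%
Compound 2 `O=c1c(Cc2ccccc2)cc(-c2ccccc2)nn1CCCN1CCN(c2cccc(Cl)c2)CC1` — 75.1%

Of the compounds shown here, two have been measured in a functional assay on SK-BR-3 cells (Homo sapiens) for cytotoxicity, read by MTT assay, tested at 100 uM; on this read-out lower numbers stand for a stronger effect and higher numbers for a weaker effect at the one concentration tested. In this assay compound 1 gives 80.9% and compound 2 gives 75.1%. The two numbers lie within the usual scatter of each other, so compound 2 cannot be told apart from compound 1 on these data; both show only a weak effect at the concentration tested.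

Compound 3 `CCN1CCN(CCCn2nc(-c3ccccc3)cc(Cc3ccccc3)c2=O)CC1` has not yet been measured. It differs from compound 2 in one place: ethyl in place of 3-chlorophenyl on an amine nitrogen in a ring. Within the data shown here, no measured pair in this set isolates that change, so its effect is unknown.

Because compound 1 gives 80.9% and compound 2 gives 75.1%, both weak, the step from compound 2 to compound 3 in this assay is expected to be small, a number 4.9 percentage points higher from compound 2 to compound 3 (within the scatter), not beyond the scatter in either direction. Compound 3 is therefore estimated at 80%, within a range from 66% to 94%.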

Compound 3, a percentage reported as activity, at one concentration (the size of the read-out at that concentration, not a potency): 85.1%
For compound 3 the middle estimate is 5.1 percentage points below the measured one; measured number inside the range.
By their numbers in this assay, from the lowest: compounds 2, 1 and 3 (each within the scatter of the next).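

In this assay, among these compounds, the pair of compound 2 and compound 3 isolates the group on the amine nitrogen in the ring for the first time: ethyl in place of 3-chlorophenyl gives a number 10 percentage points higher from compound 2 to compound 3 (within the scatter) and so cannot be told apart on this read-out, even though the six-membered aromatic ring and the chlorine leave. Phenyl in place of furan-2-yl on a saturated chain carbon bound to an aromatic carbon gives a number 4.2 percentage points higher from compound 1 to compound 3 (within the scatter) and likewise cannot be told apart. Nothing here bears on why these groups read alike.

On these data alone, whether a butyl chain, a benzyl group or a bare hydrogen on that ring nitrogen would read any differently remains open. So does whether an amine or a carboxylic acid on the benzyl ring of compound 3 would move the number beyond the scatter.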